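Swapping One Chloro for Trifluoromethyl on the Urea Aryl

This account rests on a few compounds, and the source may have more. Where it says the series, first, only, none or still open, it means among the compounds named here.

Compound 1 `COc1cc(-c2nn(-c3cccc(NC(=O)Nc4cc(C(F)(F)F)cc(C(F)(F)F)c4)c3)cc2-c2ccncc2)ccc1Cl`: 661 nM
Compound 2 `COc1cc(-c2nn(-c3cccc(NC(=O)Nc4ccc(Cl)c(Cl)c4)c3)cc2-c2ccncc2)ccc1Cl`: 773 nM
Compound 3 `O=C(Nc1cccc(-n2cc(-c3ccncc3)c(-c3ccc(Cl)c(O)c3)n2)c1)Nc1ccc(Cl)c(Cl)c1`: 1110 nM

In a functional assay on UACC-62 cells (Homo sapiens) for inhibition, read by sulforhodamine B assay, with a stated time of 48 h (on this read-out lower numbers stand for stronger inhibition of growth and higher numbers for weaker inhibition of growth), compound 2 gives 773 nM, the second highest of the three numbers; compound 1 and compound 3 both lie within the scatter of it. For the measured compounds named here, the one single-point step measured so far is a 1.4-fold higher number from compound 2 to compound 3 (0.16 log units; within the scatter). Compound 4 `COc1cc(-c2nn(-c3cccc(NC(=O)Nc4ccc(Cl)c(C(F)(F)F)c4)c3)cc2-c2ccncc2)ccc1Cl` differs from compound 2 by trifluoromethyl in place of chloro on an aromatic carbon. Going by the values given here, no measured step covers this change directly. Where compound 2 carries two chloro groups, compound 1 carries two trifluoromethyl groups and gives 661 nM, close to compound 2. Compound 4 is therefore expected to stay within the scatter of compound 2, a 1.1-fold lower number from compound 2 to compound 4 (0.04 log units; within the scatter). The estimate for compound 4 is 700 nM, with a range from 350 nM to 1400 nM.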

Compound 4, concentration for 50% growth inhibition: 737 nM
Estimate against measurement, compound 4: 1.1-fold (0.02 log units) below; measured number inside the range.
By their numbers in this assay, from the lowest: compounds 1, 4, 2 and 3 (each within the scatter of the next).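

At the position held by chloro in the 3,4-dichlorophenyl group of compound 2, trifluoromethyl, a group of four heavy atoms, replaces that single atom with a 1.0-fold lower number from compound 2 to compound 4 (0.02 log units; within the scatter) in this assay. For the compounds shown here, compound 1 differs from compound 2 in more than one place, so this is the first reading of this swap alone. Nothing measured here offers an explanation for this result. The compounds shown leave open how this position responds to a different kind of group, such as an amine or a carboxylic acid.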